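This account rests on a few compounds, and the source may have more. Where it says the series, first, only, none or still open, it means among the compounds named here.

Measured compounds:
Compound 1, `O=S(=O)(NCCNCc1ccc(-c2ccccc2)cc1)c1cc(C(F)(F)F)cc(C(F)(F)F)c1`, gives 1600 nM in a functional assay on BXPC-3 cells (Homo sapiens) for inhibition, read by MTT assay, with a stated time of 72 h; on this read-out higher numbers stand for weaker inhibition of growth and lower numbers for stronger inhibition of growth.
Compound 2, `COc1cccc(CNCCCNS(=O)(=O)c2cc(C(F)(F)F)cc(C(F)(F)F)c2)c1`, gives 1700 nM in this assay.

Both compounds share the same sulfonamide core and the same amine-bearing chain; they differ in the aromatic group at the far end and in the length of the chain. On the two numbers shown, compound 2 sits level with compound 1: the gap between them is within the usual scatter of repeated measurements, so neither can be called the stronger.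

The next compound, compound 3, is `COc1ccccc1CNCCCNS(=O)(=O)c1cc(C(F)(F)F)cc(C(F)(F)F)c1`. It has the same atoms as compound 2, joined differently: 2-methoxyphenyl in place of 3-methoxyphenyl on a saturated chain carbon bound to an amine nitrogen. Going by the values given here, no measured pair shows what such a move does here, so there is no step to lean on. Given that compound 2 gives 1700 nM in this assay, the expectation is a step no larger than the scatter, in either direction. Compound 3 is therefore estimated at 1700 nM, with a range from 700 nM to 4000 nM. The expected step is no change at the digits printed from compound 2 to compound 3 (within the scatter), which amounts to no real change.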

Compound 3, concentration for 50% growth inhibition: 1700 nM
Compound 3: middle estimate and measured number agree at the digits printed; the measured number falls inside the stated range.
By their numbers in this assay, from the lowest: compounds 1, 2 and 3 (each within the scatter of the next).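

Placing 2-methoxyphenyl in place of 3-methoxyphenyl on a saturated chain carbon bound to an amine nitrogen gives no change at the digits printed from compound 2 to compound 3 (within the scatter) in this assay. Going by these compounds alone, this is the first pair here that differs in one place, and it shows that, for this pair, the two methoxyphenyl groups cannot be told apart by growth inhibition. No measurement shown here offers an explanation for why the two compounds read alike.

Still open, going by these compounds, is whether a plain phenyl, or a hydroxyphenyl, in the same place would also stay level with compound 2. A single pair also cannot show whether this swap would read the same way on a longer chain, or on the shorter chain carried by compound 1.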